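Ethoxy to aminomethyl exchange: notes on compound 3

This account rests on a few compounds, and the source may have more. Where it says the series, first, only, none or still open, it means among the compounds named here.

Going by the values given here, compound 2 `CCOc1ccc(-c2ccc(N(C[C@@H](N)[C@@H](C)CC)C(=O)[C@@H]3C[C@H]3c3ccccc3)cc2)cc1` holds the lowest of the two numbers measured so far. In a functional assay for agonist activity at G protein-coupled receptor 88 (Homo sapiens), read by HTRF and cAMP accumulation (on this read-out higher numbers stand for an effect only at larger amounts of compound and lower numbers for an effect already at smaller amounts), compound 2 gives 90 nM, whereas compound 1 `CC[C@H](C)[C@H](N)CN(C(=O)[C@@H]1C[C@H]1c1ccc(F)c(F)c1)c1ccc(-c2ccccc2)cc1` gives 720 nM, a higher number that lies beyond the usual scatter. Compound 3 `CC[C@H](C)[C@H](N)CN(C(=O)[C@@H]1C[C@H]1c1ccccc1)c1ccc(-c2ccc(CN)cc2)cc1` differs from compound 2 by a single change, (aminomethyl in place of ethoxy on an aromatic carbon). Among the compounds with values here, no measured pair shows this exact change, so its effect is uncertain; a modest loss of activity is expected rather than none, a 2.8-fold higher number from compound 2 to compound 3 (0.44 log units; beyond the scatter). Compound 3 is estimated at 250 nM, with a plausible range from 80 nM to 800 nM.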

Compound 3, half-maximal effective concentration: > 30000 nM
Compound 3: a limit, no number; the forecaster's own chance of this, stated with the estimate: 5%; middle value at least 120-fold (2.07 log units) away from the limit.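

Compound 3 carries no number in this assay, only a limit of the assay: the limit of > 30000 nM in this assay, at which 1 of the 3 values shown sits.

Aminomethyl in place of ethoxy gives an at least 330-fold higher number from compound 2 to compound 3 (2.52 log units; beyond the scatter), the first step in the series that differs in one place. Going by these compounds alone, on this aromatic carbon, para to a large group, the choice of group can therefore decide the read-out, which the earlier compounds could not show.

The compounds shown do not separate the nitrogen of aminomethyl from its added hydrogen-bond donor or its shorter chain. A hydroxymethyl, methoxy or dimethylaminomethyl group at this place would bear on that question.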